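A few compounds are considered here, and "the series" means these few. Any claim that something is new, unique, unknown or untested is made for them only; others in the source may bear on it.

The compounds here were tested in a functional assay on HCT-116 cells (Homo sapiens) for inhibition, read by colorimetric assay, with a stated time of 3 days; a lower number here means a stronger inhibitor, a higher number a weaker inhibitor. Compound 1, with the structure `O=C(CCCCCCNC(=O)C(O)(O)C(F)(F)F)Nc1ccccc1Br`, is the only one of the two measured compounds that gives a definite number: in this assay compound 1 gives 14500 nM. Compound 2, with the structure `O=C(CCCCCCNC(=O)c1cc(=O)c(O)co1)Nc1ccccc1`, reaches only a limit of the assay, and in this assay compound 2 gives > 100000 nM. Among the compounds with values here, the picture of how the measured compounds compare is therefore thin, as the limit of > 100000 nM in this assay, at which 1 of the 2 values shown sits, shows: one definite value and one limit, so compound 1 stands alone with the single number on record.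

Compound 3, with the structure `O=C(CCCCCCNC(=O)C(O)(O)C(F)(F)F)Nc1ccc(Cl)cc1`, has not yet been measured. It differs from compound 1 by a single change on the amide-type nitrogen whose other neighbour is the carbonyl carbon: 4-chlorophenyl in place of 2-bromophenyl on an amide-type nitrogen. Within the data shown here, no pair of measured compounds differing in one place is available to show what a change of this kind does, so the expected step from compound 1 to compound 3 is a 1.2-fold lower number from compound 1 to compound 3 (0.08 log units; within the scatter), a shift of about the size of the ordinary scatter. Compound 3 is therefore expected to give roughly 12000 nM, within a range from 3500 nM to 45000 nM.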

Compound 3, half-maximal inhibitory concentration: 4230 nM
The estimate for compound 3 lay 2.8-fold (0.45 log units) above the measured number; measured number inside the range.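

On the amide-type nitrogen, 4-chlorophenyl in place of 2-bromophenyl gives a 3.4-fold lower number from compound 1 to compound 3 (0.54 log units; beyond the scatter) in this assay. Within the data shown here, that lower number means a stronger inhibitor, and this is the first sign that the aromatic group at this position affects the read-out by more than ordinary scatter. The change alters two things at once, the halogen and its place on the phenyl ring, while the rest of the structure stays the same, so this single step cannot show which of the two accounts for the shift. Nothing on record explains why the number falls, and the one limit shown has no bearing on this step.

The compounds shown leave open whether the shift follows the halogen or its place on the ring, a question that 4-bromophenyl or 2-chlorophenyl on the same nitrogen could separate when compared with compound 1 and compound 3. They also leave open how this position would respond to a phenyl ring with no halogen, or to one carrying an amine or a carboxylic acid.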